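Replacing amino with hydroxy in compound 3

The source may report more compounds than this note shows. Statements on the series, on what has been measured and on what is new or still open speak of the compounds shown alone.

In a functional assay on MDA-MB-231 cells (Homo sapiens) for antiproliferative activity, read by MTT assay, with a stated time of 72 h (on this read-out lower numbers stand for stronger inhibition and higher numbers for weaker inhibition), compound 3 `COc1ccc(-n2ccnc2-c2cc(OC)c(OC)c(OC)c2)cc1N` gives 1040 nM as the lowest of three numbers. Compound 2 `COc1ccc(-n2ccnc2-c2cc(OC)c(OC)c(OC)c2)cc1` stands at 2700 nM and compound 1 `COc1ccc(-n2ccnc2-c2cc(OC)c(OC)c(OC)c2)cc1[N+](=O)[O-]` stands at 7500 nM in this assay as well. Compound 4 `COc1ccc(-n2ccnc2-c2cc(OC)c(OC)c(OC)c2)cc1O` follows by hydroxy in place of amino on an aromatic carbon with hydroxy in place of amino on an aromatic carbon, ortho to a methoxy group. Three measured steps at this carbon bear on it: a 2.8-fold lower number from compound 1 to compound 2 (0.44 log units; beyond the scatter) and a 2.6-fold lower number from compound 2 to compound 3 (0.41 log units; beyond the scatter) and a 7.2-fold lower number from compound 1 to compound 3 (0.86 log units; beyond the scatter) are all modest. Going by the values given here, no hydroxy compound has been measured, so the direction stays open. A small change with no firm direction is expected in this assay with a 1.2-fold higher number from compound 3 to compound 4 (0.06 log units; within the scatter) as the estimated step. Compound 4 is estimated at 1200 nM within an expected range from 350 nM to 4000 nM in this series.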

Compound 4, half-maximal inhibitory concentration: 1900 nM
The estimate for compound 4 lay 1.6-fold (0.20 log units) below the measured number, within the range that was stated.
By their numbers in this assay, from the lowest: compounds 3, 4 and 2 (each within the scatter of the next, the first and the last beyond it); then compound 1.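

In this assay, hydroxy in place of amino gives a 1.8-fold higher number from compound 3 to compound 4 (0.26 log units; within the scatter) and hydroxy in place of hydrogen gives a 1.4-fold lower number from compound 2 to compound 4 (0.15 log units; within the scatter), so at this carbon hydroxy is not separated from either amino or hydrogen, although compound 2 and compound 3 are separated from each other. Hydroxy in place of nitro gives a 3.9-fold lower number from compound 1 to compound 4 (0.60 log units; beyond the scatter), which leaves compound 1 as the one compound apart from compound 4. No measurement on hand accounts for these steps.

Going by these compounds, whether a methylamino group, an acetamide or a fluorine at this carbon would fall with compound 2, compound 3 and compound 4 or with compound 1 stays open. Also open, on these data alone, is whether the steps seen here would hold with the methoxy group on that ring replaced by an ethoxy group.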